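The compounds below may be only part of what the source reports. "The series", "measured", "known", "first", "only" and "open" are said of these compounds alone.

The measured compounds:

Compound 1 `Cc1nnc(CNC(=O)CN)n1-c1ccc(Cl)cc1C(=O)c1ccccc1`, in a functional assay on the whole organism with Mus musculus as the target (on this read-out higher numbers stand for an effect only at larger amounts of compound and lower numbers for an effect already at smaller amounts), compound 1 gives 0.38 mg/kg.
Compound 2 `CN(C(=O)CNC(=O)CN)c1ccc(Cl)cc1C(=O)c1ccccc1Cl`, compound 2 gives 0.56 mg/kg.
Compound 3 `Cc1nnc(CNC(=O)CN)n1-c1ccc(Cl)cc1C(=O)c1ccccc1Cl`, compound 3 gives 0.26 mg/kg.

Compound 1 and compound 3 share one core and differ in a single place: hydrogen in place of chloro on an aromatic carbon. In this assay that change made a 1.5-fold higher number from compound 3 to compound 1 (0.16 log units; within the scatter), a step the data describe as within the scatter, so the two values are taken as equivalent. Compound 2 rests on a different core; how that core differs from the core of compound 3 is not broken down here. Compound 2 stands with the highest of the three numbers, close to compound 1 and further from compound 3.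

Compound 4 `CN(C(=O)CNC(=O)CN)c1ccc(Cl)cc1C(=O)c1ccccc1` has not yet been measured. It differs from compound 2 in one place: hydrogen in place of chloro on an aromatic carbon. Since the place of this change reads the same as the place of the change from compound 3 to compound 1, it is the same change, applied to the other core. Among the compounds with values here, only one prior example of it is available, on compound 3, and it produced a step within the scatter. Within the data shown here, the expected step from compound 2 to compound 4 is estimated as a 1.3-fold higher number from compound 2 to compound 4 (0.13 log units; within the scatter), resting on the single earlier example a 1.5-fold higher number from compound 3 to compound 1 (0.16 log units; within the scatter), with no second example to confirm that it carries over to the core of compound 2. On that basis compound 4 is expected to give about 0.75 mg/kg in this assay, with a plausible range estimated from 0.35 mg/kg to 1.6 mg/kg.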

Compound 4, dose for half-maximal effect: 2.16 mg/kg
Compound 4: the middle estimate sits 2.9-fold (0.46 log units) below what was measured; the whole stated range lies below it.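

On the core of compound 2, hydrogen in place of chloro gave, in this assay, a 3.9-fold higher number from compound 2 to compound 4 (0.59 log units; beyond the scatter), a step beyond the scatter, whereas the same change on the core of compound 3 gave a 1.5-fold higher number from compound 3 to compound 1 (0.16 log units; within the scatter), a step within it. Within the data shown here, although only one of the two steps lies beyond the scatter, the gap between them does not separate them: the same change on two cores in this assay, a 1.5-fold higher number (0.16 log units; within the scatter) from compound 3 to compound 1 and a 3.9-fold higher number (0.59 log units; beyond the scatter) from compound 2 to compound 4, 2.6-fold (0.42 log units) apart, within the scatter of two such steps. Among these compounds, the series therefore does not show that the size of this step depends on the core, nor does it show that the step carries over unchanged from one core to the other, since it rests on only two examples, one of which lies within the scatter.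

The compounds shown leave open whether a fluoro, a bromo or a methyl group in the place of the chloro, on the same aromatic carbon, would read like chloro or like hydrogen on either core. They also leave open whether the change from 2-chlorophenyl to phenyl would give a step of similar size on a third core, such as one carrying a longer chain in place of the aminoacetyl chain that both cores share.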